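The source may hold more compounds than are shown below. What is called first, only, known or untested is meant among the compounds shown, and "the series" means these compounds.

Measured so far:
compound 1, `FC(F)=C(F)CCSc1ncc(Cl)s1`: > 120000 nM
compound 2, `FC(F)=C(F)CCSc1nc2ccc(OC(F)F)cc2[nH]1`: > 120000 nM

Compound 1, `FC(F)=C(F)CCSc1ncc(Cl)s1`, was tested in a functional assay on SH-SY5Y cells (Homo sapiens) for cytotoxicity, read by MTT assay, with a stated time of 48 h; a lower number here means a stronger inhibitor, a higher number a weaker inhibitor. There compound 1 gives > 120000 nM, which is a limit of the assay rather than a measured number. Compound 2, `FC(F)=C(F)CCSc1nc2ccc(OC(F)F)cc2[nH]1`, shares the same chain and the same sulfur link but carries a different ring system; in this assay compound 2 gives > 120000 nM, again a limit and not a number. So the whole picture for compound 1 is the limit of > 120000 nM in this assay, at which 2 of the 2 values shown sit, and neither compound shows any measurable cytotoxicity on these cells.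

Compound 3, `FC(F)=C(F)CCSc1ncc(-c2ccncc2)s1`, has not yet been measured. It differs from compound 1 in one place: pyridin-4-yl in place of chloro on an aromatic carbon. The sulfur-linked chain and the five-membered core stay the same; only the group on the aromatic carbon changes.

Among the measured compounds shown here, no step between measured compounds exists to lean on, since both known values are limits. With nothing pointing toward measurable activity, the expected step in this assay is none beyond the scatter, that is a number no higher from compound 1 to compound 3 (the limit leaves the size open). Compound 3 is therefore expected to give about 120000 nM, within 50000 nM to 250000 nM, most likely again reported only as a limit.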

Compound 3, half-maximal inhibitory concentration: > 120000 nM
Compound 3 gave a limit, no number; the forecaster's own chance of this, stated with the estimate: 75%; the middle value sits exactly at the limit.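

In this assay compound 3 gives > 120000 nM as a limit of the assay and not a number. Compound 1 also stands at a limit, so no step can be read from compound 1 to compound 3. Going by these compounds, whether pyridin-4-yl in place of chloro changes cytotoxicity on these cells at all stays open.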